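Chain extension on the unsaturated amide of compound 3

The source may report more compounds than this note shows. Statements on the series, on what has been measured and on what is new or still open speak of the compounds shown alone.

The series shares one core. Compound 1 `CCC/C=C/C(=O)Nc1cc2c(N3CCCc4ccccc43)ncnc2cc1OC` carries a methoxy group and a pent-1-en-1-yl amide; in a functional assay on PC-3 cells (Homo sapiens) for antiproliferative activity, read by MTT assay, with a stated time of 72 h (a lower number here means a stronger inhibitor, a higher number a weaker inhibitor), compound 1 gives 2240 nM. Compound 2 `CC(C)=CC(=O)Nc1cc2c(N3CCCc4ccccc43)ncnc2cc1O[C@@H]1CCOC1` carries the tetrahydrofuranyloxy group with a 2-methylprop-1-en-1-yl amide, and in this assay compound 2 gives 9020 nM. Compound 3 `CC/C=C/C(=O)Nc1cc2c(N3CCCc4ccccc43)ncnc2cc1O[C@@H]1CCOC1` keeps that ether with a but-1-en-1-yl amide, and in this assay compound 3 gives 14300 nM, the largest of the three numbers shown; the step of a 1.6-fold higher number from compound 2 to compound 3 (0.20 log units; within the scatter) lies within the scatter, while the gap to compound 1 lies beyond it.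

Compound 4 `CCC/C=C/C(=O)Nc1cc2c(N3CCCc4ccccc43)ncnc2cc1O[C@@H]1CCOC1` differs from compound 3 by methyl in place of hydrogen on a saturated chain carbon, two bonds along the chain from a double-bonded chain carbon. Going by the values given here, no measured step isolates this change: compound 1 and compound 3 differ in two places at once, so their values show only that the methoxy compound with the longer chain has the lower number. Among the compounds with values here, the single step in this assay, from compound 2 to compound 3, was within the scatter. For compound 4 a step of a 1.4-fold lower number from compound 3 to compound 4 (0.16 log units; within the scatter) is therefore expected, with no clear direction beyond the scatter. Compound 4 is estimated at 10000 nM, within 3000 nM to 30000 nM.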

Compound 4, half-maximal inhibitory concentration: 11800 nM
For compound 4 the middle estimate is 1.2-fold (0.07 log units) below the measured one; the measured number falls inside the stated range.
By their numbers in this assay, from the lowest: compound 1; then compounds 2, 4 and 3 (each within the scatter of the next).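

In this assay, methyl in place of hydrogen on a saturated chain carbon, two bonds along the chain from a double-bonded chain carbon, gives a 1.2-fold lower number from compound 3 to compound 4 (0.08 log units; within the scatter), so but-1-en-1-yl to pent-1-en-1-yl does not separate the two amides. The unbranched pent-1-en-1-yl amide also shows no separation from the 2-methylprop-1-en-1-yl amide, with a 1.3-fold higher number from compound 2 to compound 4 (0.12 log units; within the scatter). With the pent-1-en-1-yl amide held constant, the ether change can now be read alone: oxolan-3-yl in place of methyl on an oxygen on an aromatic ring gives a 5.3-fold higher number from compound 1 to compound 4 (0.72 log units; beyond the scatter), and no evidence on the origin of these steps is available.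

On these data alone, it remains open whether a longer chain such as hept-1-en-1-yl, or a dimethylamino group on the amide chain, would move the number beyond the scatter. As far as these compounds go, the ether comparison also rests on one pair, so its size with other amides remains open.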